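The source may report more compounds than this note shows. Statements on the series, on what has been measured and on what is new or still open speak of the compounds shown alone.

In an ADME assay on L02 cells (Homo sapiens) for cytotoxicity, read by MTT assay, with a stated time of 72 h (on this read-out lower numbers stand for stronger inhibition and higher numbers for weaker inhibition), the three measured compounds sit as follows.
Compound 1 `CC/C=C/C(=O)Nc1cccc(Oc2nc(Nc3ccn(C)n3)nc3c2CSCC3)c1` gives > 50000 nM, which is a limit of the assay and not a number.
Compound 2 `CC(C)/C=C/C(=O)Nc1cccc(Oc2nc(Nc3ccn(C)n3)nc3c2CSCC3)c1` gives > 50000 nM, again a limit of the assay.
Compound 3 `C/C=C/C(=O)Nc1cccc(Oc2nc(Nc3cccc(C#N)c3)nc3c2CSCC3)c1` gives > 50000 nM, also a limit of the assay.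

Compound 2 arises from compound 1 by methyl in place of hydrogen on a saturated chain carbon bound to a double-bonded chain carbon and a saturated chain carbon. Within the data shown here, because both sit at the limit of > 50000 nM in this assay, at which 3 of the 3 values shown sit, the step that the two limits leave unreadable from compound 1 to compound 2 cannot be read; only that neither compound shows measurable cytotoxicity up to that limit. Compound 3 carries a different core from compound 1, and the difference between the two cores is not broken down here.

Compound 4 `CC/C=C/C(=O)Nc1cccc(Oc2nc(Nc3cccc(C#N)c3)nc3c2CSCC3)c1` is not yet measured. It arises from compound 3 by methyl in place of hydrogen on a saturated chain carbon bound to a double-bonded chain carbon. Among the measured compounds shown here, this is the same kind of change as the one from compound 1 to compound 2, though not the same: the place in compound 1 is bound to a double-bonded chain carbon and a saturated chain carbon, whereas in compound 3 it is bound to a double-bonded chain carbon only. In this assay compound 4 is expected to stay at the limit, with an estimated step that the limit leaves unreadable from compound 3 to compound 4, because compound 3 and both earlier compounds all sit at the limit of > 50000 nM in this assay, at which 3 of the 3 values shown sit. The estimate for compound 4 is therefore 60000 nM, spanning 30000 nM to 120000 nM.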

Compound 4, half-maximal inhibitory concentration: > 50000 nM
Compound 4: no number, only a limit (the forecaster's own chance of this, stated with the estimate: 85%); the middle value is on the limit's open side.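

Compound 4 gives > 50000 nM in this assay, which is a limit of the assay and not a number. The steps from compound 3 and from compound 1 to compound 4 cannot be read, because no value shown is an actual number: the limit of > 50000 nM in this assay, at which 4 of the 4 values shown sit. Still open, from the compounds shown here alone, is whether any of these changes alters cytotoxicity in these cells at all.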